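The compounds below may be only part of what the source reports. "The series", "measured", "known", "first", "only" and "open" are said of these compounds alone.

The measured compounds:
compound 1, `NC1CCC(Nc2nc(NCc3ccc(-c4ccsc4)cc3)c3ncn(C4CCCC4)c3n2)CC1`, 150 nM in a functional assay on K562 cells (Homo sapiens) for inhibition, with a stated time of 72 h; on this read-out lower numbers stand for stronger inhibition and higher numbers for weaker inhibition
compound 2, `NC1CCC(Nc2nc(NCc3ccc(-c4ccsc4)nc3)c3ncn(C4CCCC4)c3n2)CC1`, 150 nM in this assay
compound 3, `NC1CCC(Nc2nc(NCc3ccc(-c4ccccc4O)cc3)c3ncn(C4CCCC4)c3n2)CC1`, 2610 nM in this assay

Compound 1 and compound 2 share a core and differ only in the group attached to the saturated chain carbon: 6-(thiophen-3-yl)pyridin-3-yl in place of 4-(thiophen-3-yl)phenyl on a saturated chain carbon bound to a nitrogen on an aromatic ring. That swap left the read-out where it was, no change at the digits printed from compound 1 to compound 2 (within the scatter). Compound 3 keeps the core of compound 1 but carries a different ring at its far end: 2-hydroxyphenyl in place of thiophen-3-yl on an aromatic carbon. This step weakened the inhibition markedly, a 17-fold higher number from compound 1 to compound 3 (1.24 log units; beyond the scatter).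

Compound 4, `NC1CCC(Nc2nc(NCc3ccc(-c4ccccc4O)nc3)c3ncn(C4CCCC4)c3n2)CC1`, has not yet been measured in this assay. It stands to compound 2 as compound 3 stands to compound 1: 2-hydroxyphenyl in place of thiophen-3-yl on an aromatic carbon. Among the compounds with values here, the change is the same kind of change as the one from compound 1 to compound 3, not the same, since its place differs: in compound 1 the group sits on an aromatic carbon of a six-membered aromatic ring of carbon only, para to a large group, while in compound 2 it sits on an aromatic carbon of a six-membered aromatic ring with 1 nitrogen, next to the ring nitrogen, para to a large group. Compound 1 and compound 2 gave the same number, so the step from compound 2 to compound 4 is expected to be of similar size, a 16-fold higher number from compound 2 to compound 4 (1.20 log units; beyond the scatter), set beside the measured 17-fold higher number from compound 1 to compound 3 (1.24 log units; beyond the scatter). Within the data shown here, that expectation rests only on compound 1 and compound 3, because a 17-fold higher number from compound 1 to compound 3 (1.24 log units; beyond the scatter) is the single measured instance of this change. For compound 4 in this assay the estimate is 2400 nM, with a likely range from 900 nM to 6500 nM.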

Compound 4, half-maximal inhibitory concentration: 16 nM
The estimate for compound 4 lay 150-fold (2.18 log units) above the measured number; the measured number lies below the stated range.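

On the core of compound 2, putting 2-hydroxyphenyl in place of thiophen-3-yl gave a 9.4-fold lower number from compound 2 to compound 4 (0.97 log units; beyond the scatter) in this assay, so the change that weakened inhibition on the core of compound 1 strengthened it here. In these two pairs, the effect of this change did not carry from one core to the other, in either size or direction: the same change on two cores in this assay, a 17-fold higher number (1.24 log units; beyond the scatter) from compound 1 to compound 3 and a 9.4-fold lower number (0.97 log units; beyond the scatter) from compound 2 to compound 4, 160-fold (2.21 log units) apart, beyond the scatter of two such steps This shows that the outcome of the swap depends on the core that carries it, even though the cores differ only by a ring nitrogen and compound 1 and compound 2 gave the same number, but it does not show why the direction reverses, and two pairs cannot establish a rule for any other group in this series.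

The compounds shown leave open whether the reversal belongs to the hydroxyl itself or to the added phenyl ring, a question that a plain phenyl, a 2-methoxyphenyl or a 2-aminophenyl group on both cores could help to settle. They also leave open whether the strong inhibition by compound 4 holds in other cell lines or at other exposure times.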